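From Compound 3 to Compound 4 in the Tail Flick Test

This account rests on a few compounds, and the source may have more. Where it says the series, first, only, none or still open, it means among the compounds named here.

Of the compounds shown here, three built on a shared core have been tested in a functional assay on the whole organism (Tail, strain ICR) with Mus musculus as the target, in the tail flick test, with a stated time of 120 min, at a dose of 25 umol/kg by the oral route; a lower number here means a weaker effect, a higher number a stronger effect of the compound at the dose given. Compound 1 `O=C(CN(c1nc(Cl)nc2[nH]cnc12)C1CC1)N[C@@H](CC(=O)OCc1ccccc1)C(=O)OCc1ccccc1` gives 12.1% in this assay. Compound 2 `CSCC[C@H](NC(=O)CN(c1ncnc2c1ncn2C1CCCCO1)C1CC1)C(=O)OCc1ccccc1` gives 28.7% in this assay. Compound 3 `O=C(O)C[C@H](NC(=O)CN(c1nc(Cl)nc2[nH]cnc12)C1CC1)C(=O)O` gives 22% in this assay, the second highest of the three numbers; its nearest neighbour is compound 2, a number higher by an amount within the usual scatter, and its furthest is compound 1, a number lower by an amount also within the scatter. Among the measured compounds shown here, none of the three pairs differs in a single place, so no step between measured compounds can be read from these numbers.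

Compound 4 `NCCCC[C@H](NC(=O)CN(c1nc(Cl)nc2[nH]cnc12)C1CC1)C(=O)O` has not yet been measured in this assay. It differs from compound 3 as follows: 3-aminopropyl in place of carboxy on a saturated chain carbon, two bonds along the chain from an amide-type nitrogen and a carbonyl carbon. For the measured compounds named here, with no measured step of this kind to lean on, the expected change is small, in no settled direction, and most likely none beyond the scatter. The expected step is no change at the digits printed from compound 3 to compound 4 (within the scatter). Compound 4 is thus estimated at 22% in this assay, with a range from 8% to 40%.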

Compound 4, a percentage reported as activity, at one dose (the size of the read-out at that dose, not a potency): 16.4%
The estimate for compound 4 lay 5.6 percentage points above the measured number, within the range that was stated.
By their numbers in this assay, from the lowest: compounds 1, 4, 3 and 2 (each within the scatter of the next, the first and the last beyond it).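

In this assay, 3-aminopropyl in place of carboxy on a saturated chain carbon, two bonds along the chain from an amide-type nitrogen and a carbonyl carbon, gives a number 5.6 percentage points lower from compound 3 to compound 4 (within the scatter). Among the compounds shown here, this is the first single-place step, and it shows that at this position a carboxymethyl side chain and a 4-aminobutyl side chain cannot be told apart in this read-out, though the two chains end in different groups. No measurement is at hand that bears on what lies behind this result.

The compounds shown leave open whether a hydroxyl group, a primary amide or a longer amine chain at this position would give a step beyond the scatter. They also leave open whether a simple methyl group there would read the same.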